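Swapping the amide substituent in a growth hormone secretagogue agonist

The source may hold more compounds than are shown below. What is called first, only, known or untested is meant among the compounds shown, and "the series" means these compounds.

Three compounds have been measured:

- compound 1, `Cc1ccc2[nH]c(C(=O)N[C@H]3CCN(S(=O)(=O)c4cccnc4)C[C@@H]3C(=O)NCCN(C)C)cc2c1`, 93%
- compound 2, `Cc1ccc2[nH]c(C(=O)N[C@@H]3CCN(S(=O)(=O)c4ccccc4)C[C@@H]3C(=O)NCCN(C)C)cc2c1`, 93%
- compound 3, `Cc1ccc2[nH]c(C(=O)N[C@H]3CN(S(=O)(=O)c4ccccc4)C[C@@H]3C(=O)NC[C@H]3CCCN3)cc2c1`, 94%

All three share a core and differ in the ring that caps the sulfonamide and in the group attached to the amide-type nitrogen. In a functional assay on HEK293 cells for agonist activity at growth hormone secretagogue receptor type 1 (Homo sapiens), read by HTRF and inositol phosphate accumulation, with a stated time of 90 min, in the presence of a further agent that is not named here (a higher number here means a larger maximal response, a lower number a smaller maximal response), compound 3 gives 94%. Compound 1 and compound 2 give values that sit within the usual scatter of compound 3, so the three cannot be ranked against one another on these numbers; each of them reaches close to the full response of the reference.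

Compound 4, `Cc1ccc2[nH]c(C(=O)N[C@H]3CN(S(=O)(=O)c4ccccc4)C[C@@H]3C(=O)N[C@@H]3CCCN(C)C3)cc2c1`, has not yet been measured. It differs from compound 3 in one place: 1-methylpiperidin-3-yl in place of (pyrrolidin-2-yl)methyl on an amide-type nitrogen. Among the measured compounds shown here, no pair of measured compounds that differ in one place is available, so the size of this step cannot be read from earlier data. Since every measured compound, whatever its amide substituent, reaches nearly the full response, no step beyond the scatter is expected in this assay. Compound 4 is therefore estimated to give 92%, between 82% and 100%, which means an expected step of a number 2 percentage points lower from compound 3 to compound 4 (within the scatter).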

Compound 4, largest response reached (Emax), in percent of the reference or control that the assay uses: 91%
Beside the measured number, compound 4's estimate is 1 percentage points above it; low and high end bracket the measured number.
By their numbers in this assay, from the lowest: compounds 4, 1, 2 and 3 (each within the scatter of the next).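

In this assay, among the compounds shown here, putting 1-methylpiperidin-3-yl in place of (pyrrolidin-2-yl)methyl on the amide-type nitrogen gives a number 3 percentage points lower from compound 3 to compound 4 (within the scatter), the first step here in which only this one group differs. The two compounds cannot be told apart on this read-out, even though the swap replaces a five-membered ring with a six-membered one and the entering group has 0 hydrogen-bond donors, so at this position, neither difference, in this one pair, shifts the maximal response beyond the scatter. Nothing available explains why the response holds across this swap.

Going by these compounds, whether the response would hold with a carboxylic acid or a plain butyl chain on this nitrogen remains open. The largest response also leaves open how much of each compound is needed to reach it.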